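The source may report more compounds than this note shows. Statements on the series, on what has been measured and on what is new or still open speak of the compounds shown alone.

Compound 2, `CC(C)[C@H](NC(=O)COc1cccc2ccccc12)C(=O)N[C@@H](CC(=O)O)C(=O)COc1nncc(Cl)c1Cl`, carries a 4,5-dichloropyridazin-3-yl group on an oxygen on a saturated carbon. In a functional assay on Jurkat cells (Homo sapiens) for inhibition (a higher number here means a weaker inhibitor, a lower number a stronger inhibitor), compound 2 gives only a limit of the assay, > 200000 nM. Its neighbour compound 1, `CC(C)[C@H](NC(=O)COc1cccc2ccccc12)C(=O)N[C@@H](CC(=O)O)C(=O)COc1cc(C(F)(F)F)ncn1`, differs only in bearing a 6-(trifluoromethyl)pyrimidin-4-yl group at that oxygen. In this assay compound 1 likewise gives only a limit, > 200000 nM. Going by the values given here, the one measured step, a step that the two limits leave unreadable from compound 1 to compound 2, is therefore unreadable, since (the limit of > 200000 nM in this assay, at which 2 of the 2 values shown sit). Compound 3, `CC(C)[C@H](NC(=O)COc1cccc2ccccc12)C(=O)N[C@@H](CC(=O)O)C(=O)COn1nnc2ccccc2c1=O`, arises from compound 2 through (a group of 11 heavy atoms (7 carbon, 3 nitrogen, 1 oxygen; one six-membered aromatic ring of carbon only, one six-membered aromatic ring with 3 hetero atoms) in place of a group of 8 heavy atoms (4 carbon, 2 nitrogen, 2 chlorine; one six-membered aromatic ring with 2 hetero atoms), on an oxygen on a saturated carbon). Among the compounds with values here, no measured step bears on this change, so compound 3 is expected to give 200000 nM, within 20000 nM and 1000000 nM, which would mean an expected step of a number no higher from compound 2 to compound 3 (the limit leaves the size open).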

Compound 3, half-maximal inhibitory concentration: 137000 nM
Compound 3: the middle estimate sits 1.5-fold (0.16 log units) above what was measured; the range from low to high includes it.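

At this oxygen on a saturated carbon, compound 3 is the only one of the three to give a number rather than a limit in this assay, at 137000 nM. The change gives an at least 1.4-fold lower number from compound 2 to compound 3 (0.16 log units; that floor lies within the scatter), and it gives an at least 1.4-fold lower number from compound 1 to compound 3 (0.16 log units; that floor lies within the scatter). The true size of both steps therefore stays open, and only their floors can be read: the limit of > 200000 nM in this assay, at which 2 of the 3 values shown sit.

The compounds shown leave open whether a plain phenyl or a piperidine at this oxygen would also give a number. They also leave open whether the carbonyl of the entering group matters.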